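A few compounds are considered here, and "the series" means these few. Any claim that something is new, unique, unknown or untested is made for them only; others in the source may bear on it.

In a functional assay on MDA-MB-435 cells (Homo sapiens) for inhibition, read by sulforhodamine B assay, with a stated time of 48 h (on this read-out higher numbers stand for weaker inhibition of growth and lower numbers for stronger inhibition of growth), compound 1 `COc1ccc(C(=O)/C=C/c2cc(-c3cc(OC)c(OC)c(OC)c3)n[nH]2)cc1OC` gives 2710 nM, and compound 2 `COc1ccc(C(=O)/C=C/c2cc(-c3cc(OC)c(OC)c(OC)c3)n[nH]2)cc1` gives 5690 nM. Within the data shown here, compound 2 thus stands with the higher of the two numbers, and the one measured step, a 2.1-fold higher number from compound 1 to compound 2 (0.32 log units; beyond the scatter), was produced by taking a methoxy off the aromatic ring that sits on the carbonyl carbon. Compound 3 `COc1cc(-c2cc(/C=C/C(=O)c3ccc(F)c(F)c3)[nH]n2)cc(OC)c1OC` differs from compound 2 by 3,4-difluorophenyl in place of 4-methoxyphenyl on a carbonyl carbon, again a change on that same ring, this time swapping the remaining methoxy for two fluorines. Among the measured compounds shown here, no measured step covers an exchange of this kind, so the only guide is that stripping a methoxy from this ring already raised the number in the step from compound 1 to compound 2. For compound 3 the expectation is therefore a modest further rise, a 1.4-fold higher number from compound 2 to compound 3 (0.15 log units; within the scatter), within wide uncertainty. The estimate for compound 3 in this assay is 8000 nM, expected to lie between 2500 nM and 25000 nM.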

Compound 3, concentration for total growth inhibition: 13300 nM
Estimate against measurement, compound 3: 1.7-fold (0.22 log units) below, and the stated range covers the measured number.
By their numbers in this assay, from the lowest: compound 1; then compound 2; then compound 3.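

In this assay, this position on the carbonyl carbon now shows a second kind of change: 3,4-difluorophenyl in place of 4-methoxyphenyl gives a 2.3-fold higher number from compound 2 to compound 3 (0.37 log units; beyond the scatter), a step larger than a modest shift might suggest, as it is again beyond the scatter. Measured against the 3,4-dimethoxyphenyl ring, the same 3,4-difluorophenyl gives a 4.9-fold higher number from compound 1 to compound 3 (0.69 log units; beyond the scatter), so across these three compounds growth inhibition weakens as methoxy groups leave this ring, and the two fluorines do not win it back. Nothing measured here explains why the number rises.

Losing methoxy and gaining fluorine happen together in this swap, and the compounds shown do not tell which of the two drives the rise. A plain phenyl ring, or a hydroxyl or an amine on this ring, would be needed to separate those two readings.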